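Ethyl for chloro on the shared core: microsomal half-life

The compounds below may be only part of what the source reports. "The series", "measured", "known", "first", "only" and "open" are said of these compounds alone.

Compound 1 `CCc1nc(NC(CC)CC)c(Cl)nc1-c1ccc(Cl)cc1Cl` stands lowest of the three measured analogues: in an in vitro ADME assay on microsomes (Homo sapiens) for metabolic stability (a lower number here means that the compound disappears faster, a higher number that the compound lasts longer), compound 1 gives 0.167 h. Compound 2 `CCC(CC)Nc1nc(C)c(-c2ccc(Cl)cc2Cl)nc1C`, the nearest, gives 0.483 h in this assay, a gap beyond the scatter. Compound 3 `CCc1nc(-c2ccc(OC(F)(F)F)cc2OC)c(OC)nc1NC(CC)CC`, the furthest, gives 0.867 h in this assay, also beyond the scatter. Within the data shown here, no pair of measured compounds differs in a single place, so no measured step calibrates the change. Compound 4 `CCc1nc(-c2ccc(Cl)cc2Cl)c(CC)nc1NC(CC)CC` differs from compound 1 by ethyl in place of chloro on an aromatic carbon. Compounds 2 and 3 carry no chloro on the core and both sit higher than compound 1, but neither is a clean comparison. A modest rise in this assay is expected for compound 4, of size a 1.8-fold higher number from compound 1 to compound 4 (0.25 log units; within the scatter), near the edge of the scatter. The estimate for compound 4 is 0.3 h, ranging from 0.12 h to 0.75 h.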

Compound 4, half-life: 0.283 h
Beside the measured number, compound 4's estimate is 1.1-fold (0.03 log units) above it; measured number inside the range.
By their numbers in this assay, from the lowest: compounds 1, 4, 2 and 3 (each within the scatter of the next, the first and the last beyond it).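

Ethyl in place of chloro, on an aromatic carbon next to the ring nitrogen, gives the first single-place step of the series in this assay: a 1.7-fold higher number from compound 1 to compound 4 (0.23 log units; within the scatter). On this one pair, the change at this position does not separate the two compounds beyond the scatter. Nothing available bears on the reason for this result.

As far as these compounds go, whether a primary amine, a carboxylic acid or a longer chain such as butyl at this position would stay within the scatter remains open. From the compounds shown here alone, whether the ethyl-for-chloro step holds with a different aryl group also remains open.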